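Inverting One Ring Stereocentre in a Thromboxane Antagonist

This account rests on a few compounds, and the source may have more. Where it says the series, first, only, none or still open, it means among the compounds named here.

Compound 2 `O=C(O)CC/C=C\C[C@@H]1CN(S(=O)(=O)c2ccc(Cl)cc2)C[C@H]1c1ccccc1O` holds the lower of the two numbers on record. In a functional assay (Cavia porcellus) for antagonist activity at thromboxane A2 receptor (Homo sapiens) (on this read-out higher numbers stand for weaker binding and lower numbers for tighter binding), compound 2 gives 12.6 nM, while compound 1 `CC(C)C(=O)N1C[C@@H](C/C=C\CCC(=O)O)[C@@H](c2ccccc2O)C1` gives 200 nM, a gap well beyond the scatter; since these two compounds differ in several places at once, that gap says nothing about any single change. Compound 3 `O=C(O)CC/C=C\C[C@@H]1CN(S(=O)(=O)c2ccc(Cl)cc2)C[C@@H]1c1ccccc1O` is the diastereomer of compound 2 in which (the two compounds have the same atoms and bonds and differ only in configuration as drawn: 1 of 3 stereo elements differ; a stereocentre at a saturated ring carbon is drawn R in compound 2 and S in compound 3). Among the measured compounds shown here, no step between measured compounds shows how such an inversion plays out, so the expectation rests on the general weight a change of configuration tends to carry. Compound 3 is expected to bind less tightly, the estimated step being a 7.9-fold higher number from compound 2 to compound 3 (0.90 log units; beyond the scatter) in this assay, a size beyond the scatter. The estimate for compound 3 in this assay is 100 nM, within a range from 20 nM to 800 nM.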

Compound 3, dissociation constant: 1 nM
Estimate against measurement, compound 3: 100-fold (2.00 log units) above, outside the stated range (below it).
By their numbers in this assay, from the lowest: compound 3; then compound 2; then compound 1.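

In this assay, inverting the stereocentre at the saturated ring carbon from R to S gives a 13-fold lower number from compound 2 to compound 3 (1.10 log units; beyond the scatter), so configuration at this position alone moves the number well beyond the scatter, and the S form is the tighter binder of this pair. Compound 1 and compound 3 differ in one place, which gives the nitrogen substituent a clean reading that the earlier pair could not: (4-chlorophenyl)sulfonyl in place of isopropylcarbonyl on an amine nitrogen in a ring gives a 200-fold lower number from compound 1 to compound 3 (2.30 log units; beyond the scatter). The first step can be assigned to the inversion alone because of this: the fact that compounds 2 and 3 differ only in the configuration as drawn

The compounds shown leave open whether the inversion carries the same weight with isopropylcarbonyl on the ring nitrogen. They also leave open whether a tetrazole in place of the carboxylic acid would keep the tight binding of compound 3.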